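This account rests on a few compounds, and the source may have more. Where it says the series, first, only, none or still open, it means among the compounds named here.

Within the data shown here, in a functional assay on MCF7 cells (Homo sapiens) for antiproliferative activity, read by MTT assay, with a stated time of 48 h (on this read-out lower numbers stand for stronger inhibition and higher numbers for weaker inhibition), compound 1 `COc1cc(-c2nnc3c(OC)cc(-c4ccc5[nH]ccc5c4)cn23)cc(OC)c1OC` with methyl on an oxygen on an aromatic ring gives 80 nM as the lowest number so far. On that same oxygen, compound 2 `COc1cc(-c2nnc3c(OC4COC4)cc(-c4ccc5[nH]ccc5c4)cn23)cc(OC)c1OC` with oxetan-3-yl gives 2470 nM as the highest number. Compound 3 `COc1cc(-c2nnc3c(OCC(F)(F)F)cc(-c4ccc5[nH]ccc5c4)cn23)cc(OC)c1OC` with 2,2,2-trifluoroethyl there gives 608 nM as the second highest of the three numbers.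

Compound 4 `COc1cc(-c2nnc3c(OC4CCC4)cc(-c4ccc5[nH]ccc5c4)cn23)cc(OC)c1OC` carries the change cyclobutyl in place of 2,2,2-trifluoroethyl on an oxygen on an aromatic ring at that oxygen: cyclobutyl in place of 2,2,2-trifluoroethyl on an oxygen on an aromatic ring. Among the measured compounds shown here, no cyclobutyl compound has been measured, so the evidence is indirect. Both replacements of methyl raised the number, as seen in a 31-fold higher number from compound 1 to compound 2 (1.49 log units; beyond the scatter) and in a 7.6-fold higher number from compound 1 to compound 3 (0.88 log units; beyond the scatter) as well. The size depends on the group, as a 4.1-fold lower number from compound 2 to compound 3 (0.61 log units; beyond the scatter) shows.

A return toward compound 1 is not expected, and the wide gap between the two larger groups leaves the direction from compound 3 open. In this assay the expectation is therefore no step beyond the scatter, with any drift slightly upward. The estimate amounts to a 1.2-fold higher number from compound 3 to compound 4 (0.06 log units; within the scatter) as an expected step. Compound 4 is estimated at 700 nM with an expected range from 200 nM to 2500 nM in this series.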

Compound 4, half-maximal inhibitory concentration: 267 nM
Compound 4: middle estimate off by 2.6-fold (0.42 log units), on the high side; the range from low to high includes it.
By their numbers in this assay, from the lowest: compound 1; then compound 4; then compound 3; then compound 2.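

In this assay, cyclobutyl on the oxygen on an aromatic ring gives the lowest number yet among the replacements of methyl, with a 2.3-fold lower number from compound 3 to compound 4 (0.36 log units; beyond the scatter) as the step from the 2,2,2-trifluoroethyl group, so the gap left open between the two earlier replacements now has a direction. The largest of the new steps, a 9.3-fold lower number from compound 2 to compound 4 (0.97 log units; beyond the scatter), sets the ring of carbon only in cyclobutyl against oxetan-3-yl and shows that much of the number depends on the identity of the group, not simply on a ring being present at this oxygen. Methyl nevertheless remains the best group here, with a 3.3-fold higher number from compound 1 to compound 4 (0.52 log units; beyond the scatter) as the remaining cost, and all three replacements of methyl raise the number with no compound going against that pattern.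

Nothing available explains why these groups rank as they do.
Still open, as far as these compounds go, is whether an ethyl or isopropyl chain, a cyclopropyl ring or a cyclopentyl ring on this oxygen would come closer to compound 1, and how a longer chain ending in an amine or a hydroxyl group would fit into this order.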